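The source may report more compounds than this note shows. Statements on the series, on what has been measured and on what is new or still open speak of the compounds shown alone.

Working notes on the series. For the measured compounds named here, compound 1 `CC(C)c1csc(/C=C/c2cccc([C@@H](CCc3ccccc3C(C)(C)O)SCC3(CC(=O)O)CC3)c2)n1` carries an isopropyl group on its thiazole; in an assay on membranes from lung for inhibition of cysteinyl leukotriene receptor 1 (Cavia porcellus) (a lower number here means a stronger inhibitor, a higher number a weaker inhibitor), compound 1 gives 1.9 nM, the only value shown for it as a single number, alongside a further entry that gives no single number. Going by the values given here, compound 2 `CC(CC(F)(F)F)c1csc(/C=C/c2cccc([C@@H](CCc3ccccc3C(C)(C)O)SCC3(CC(=O)O)CC3)c2)n1` is the only other compound measured; in this assay compound 2 gives 0.7 nM; 1 nM (2 entries), and the spread among its own repeated entries the several entries of compound 2 in this assay, 0.7 nM; 1 nM (2 entries) shows how far two readings of one compound can lie apart here. Among the compounds with values here, no pair of measured compounds differs in exactly one place, so no measured step is available.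

Compound 3 `CC(C)(O)c1ccccc1CC[C@@H](SCC1(CC(=O)O)CC1)c1cccc(/C=C/c2nc(C3CCCCC3)cs2)c1` is to be measured in this assay. Against compound 1 the change is cyclohexyl in place of isopropyl on an aromatic carbon, a larger saturated carbon ring replacing a short branched chain at the same position. Without a measured step of this kind, the step from compound 1 to compound 3 is expected to be small, within the usual scatter, with no clear direction. Compound 3 is thus estimated at 1.5 nM in this assay, within a range from 0.5 nM to 5 nM, which corresponds to an expected step of a 1.3-fold lower number from compound 1 to compound 3 (0.10 log units; within the scatter).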

Compound 3, half-maximal inhibitory concentration: 2.1 nM
For compound 3 the middle estimate is 1.4-fold (0.15 log units) below the measured one; the range from low to high includes it.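

The step at this position reads a 1.1-fold higher number from compound 1 to compound 3 (0.04 log units; within the scatter) in this assay, so the isopropyl and cyclohexyl groups cannot be told apart by this reading. Going from 3 to 6 heavy atoms, and adding a six-membered non-aromatic ring of carbon only, therefore leaves no measurable mark here. The step is no wider than the gap between readings of a single compound: the several entries of compound 2 in this assay, 0.7 nM; 1 nM (2 entries).

Isopropyl and cyclohexyl both carry 0 hydrogen-bond donors and 0 hydrogen-bond acceptors, so it remains open whether an amine, a hydroxyl group or a phenyl ring at this position would move the number beyond the scatter. This single step also cannot show how far the tolerance extends, for instance to a longer chain or a larger carbon ring.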